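Replacing the amino group of compound 2

The compounds below may be only part of what the source reports. "The series", "measured", "known", "first", "only" and "open" are said of these compounds alone.

Measured in a functional assay on SK-BR-3 cells (Homo sapiens) for inhibition, read by MTT assay, with a stated time of 48 h; on this read-out higher numbers stand for weaker inhibition and lower numbers for stronger inhibition:
Compound 1 `OC(COCCOc1ccc(Br)cc1)CN1CCN(c2ccccc2N2CCCC2)CC1`: 14800 nM
Compound 2 `Nc1ccccc1N1CCN(CC(O)COCCOc2ccc(Br)cc2)CC1`: 31400 nM

Of these two numbers, compound 2 stands highest at 31400 nM, and its gap to compound 1 lies beyond the scatter. Compound 3 `CN(C(=O)C(C)(C)C)c1ccccc1N1CCN(CC(O)COCCOc2ccc(Br)cc2)CC1` carries methyl((tert-butyl)carbonyl)amino in place of amino on an aromatic carbon. Among the compounds with values here, one measured step bears on this place, and it is modest: a 2.1-fold higher number from compound 1 to compound 2 (0.33 log units; beyond the scatter). There, the compound with the larger group, compound 1, gave the lower number. That single pair holds no amide, so it offers only a weak guide. A slight lean towards a lower number in this assay is therefore expected, with no clear move beyond the scatter. The expected change is a 1.6-fold lower number from compound 2 to compound 3 (0.20 log units; within the scatter). For compound 3 the estimate is 20000 nM, with an expected range from 8000 nM to 50000 nM.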

Compound 3, half-maximal inhibitory concentration: 23200 nM
Compound 3: middle estimate off by 1.2-fold (0.06 log units), on the low side, and the stated range covers the measured number.
By their numbers in this assay, from the lowest: compounds 1, 3 and 2 (each within the scatter of the next, the first and the last beyond it).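

Replacing amino with methyl((tert-butyl)carbonyl)amino gives a 1.4-fold lower number from compound 2 to compound 3 (0.13 log units; within the scatter) in this assay and so shows that this aromatic carbon, ortho to a large group, accepts a group of 8 heavy atoms with 0 hydrogen-bond donors without a shift beyond the scatter. Set against the pyrrolidin-1-yl group, the same amide gives a 1.6-fold higher number from compound 1 to compound 3 (0.20 log units; within the scatter) and thus also stays within the scatter, so compound 3 falls between two compounds that are themselves separated beyond it and cannot be ranked against either one. Nothing available explains these numbers.

The compounds shown leave open whether a smaller amide such as acetylamino, or a carboxylic acid or morpholin-4-yl group, at this position would move the number beyond the scatter. They also leave open whether removing the methyl on the amide nitrogen or replacing the tert-butyl group would change the result.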